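Swapping the Aryl Amide for a Furan Amide

The compounds below may be only part of what the source reports. "The series", "measured", "known", "first", "only" and "open" are said of these compounds alone.

Among the three amides measured in an assay on CHO cells for displacement of a labelled ligand from adenosine receptor A3 (Homo sapiens), read by scintillation counting (a lower number here means a stronger inhibitor, a higher number a weaker inhibitor), compound 3 `O=C(Nc1nc(-c2ccccc2)nc2c1nnn2Cc1ccccc1)c1ccccc1C(F)(F)F` stands at the lowest number, giving 560 nM. Compound 2 `Nc1ccc(C(=O)Nc2nc(-c3ccccc3)nc3c2nnn3Cc2ccccc2)cc1` gives 926 nM, and compound 1 `O=C(Nc1nc(-c2ccccc2)nc2c1nnn2Cc1ccccc1)c1cccc([N+](=O)[O-])c1` gives 4850 nM. The two steps that bear on the next change are an 8.7-fold lower number from compound 1 to compound 3 (0.94 log units; beyond the scatter) and a 1.7-fold lower number from compound 2 to compound 3 (0.22 log units; within the scatter), both replacements of the group on the carbonyl carbon. Compound 4 `O=C(Nc1nc(-c2ccccc2)nc2c1nnn2Cc1ccccc1)c1ccoc1` carries the change (furan-3-yl in place of 2-(trifluoromethyl)phenyl on a carbonyl carbon). For the measured compounds named here, no measured step covers a five-membered ring there, so the expected step of a 2.1-fold higher number from compound 3 to compound 4 (0.33 log units; beyond the scatter) rests on the spread of the three aryl amides rather than a direct precedent. Compound 4 is therefore expected to give about 1200 nM in this assay, within a range from 300 nM to 5000 nM.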

Compound 4, inhibition constant: 1640 nM
The estimate for compound 4 lay 1.4-fold (0.14 log units) below the measured number; the range from low to high includes it.
By their numbers in this assay, from the lowest: compounds 3, 2 and 4 (each within the scatter of the next, the first and the last beyond it); then compound 1.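

The furan-3-yl amide shows that a five-membered ring with a hetero atom on this carbonyl carbon reads between two of the aryl amides in this assay, with both steps beyond the scatter: (a 2.9-fold higher number from compound 3 to compound 4 (0.47 log units; beyond the scatter)) and (a 3.0-fold lower number from compound 1 to compound 4 (0.47 log units; beyond the scatter)). Against the 4-aminophenyl amide, the step (a 1.8-fold higher number from compound 2 to compound 4 (0.25 log units; within the scatter)) does not separate the two groups. Nothing available here explains these steps.

The compounds shown leave open whether a thiophene or a pyridine on this carbonyl carbon would read like furan-3-yl, and what a plain alkyl chain with no ring would give.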